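The source may hold more compounds than are shown below. What is called first, only, known or untested is meant among the compounds shown, and "the series" means these compounds.

Measured compounds and their values:
Compound 1, `COc1cc(-c2nn(-c3cccc(NC(=O)c4ccc(Cl)c(C(F)(F)F)c4)c3)cc2-c2ccncc2)ccc1Cl`: in a functional assay on SF-295 cells (Homo sapiens) for inhibition, read by sulforhodamine B assay, with a stated time of 48 h (a higher number here means a weaker inhibitor of growth, a lower number a stronger inhibitor of growth), compound 1 gives 17300 nM.
Compound 2, `COc1cc(-c2nn(-c3cccc(NC(=O)c4cccc(C(F)(F)F)c4)c3)cc2-c2ccncc2)ccc1Cl`: in this assay compound 2 gives 3000 nM.
Compound 3, `COc1cc(-c2nn(-c3cccc(NC(=O)Nc4ccc(Cl)c(C(F)(F)F)c4)c3)cc2-c2ccncc2)ccc1Cl`: in this assay compound 3 gives 2540 nM.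

Among these three, compound 3 carries the lowest number. Its nearest neighbour is compound 2, and the gap is small: a 1.2-fold lower number from compound 2 to compound 3 (0.07 log units; within the scatter). The furthest is compound 1: a 6.8-fold lower number from compound 1 to compound 3 (0.83 log units; beyond the scatter). The other measured step, a 5.8-fold lower number from compound 1 to compound 2 (0.76 log units; beyond the scatter), removes a chloro from an aromatic carbon.

Compound 4, `O=C(Nc1cccc(-n2cc(-c3ccncc3)c(-c3ccc(Cl)c(O)c3)n2)c1)Nc1ccc(Cl)c(C(F)(F)F)c1`, differs from compound 3 in a single place: hydrogen in place of methyl on an oxygen on an aromatic ring. Read one bond further out, this is methoxy to hydroxy, or 4-chloro-3-methoxyphenyl to 4-chloro-3-hydroxyphenyl. Within the data shown here, none of the measured steps touches this oxygen or its methyl: the two changes seen so far concern the chloro on an aromatic carbon and the group on the carbonyl carbon. Among the measured compounds shown here, there is therefore no step in this set that speaks directly to the change from compound 3 to compound 4, and the plain expectation is a step that stays within the scatter, in either direction, so a 1.0-fold lower number from compound 3 to compound 4 (0.01 log units; within the scatter) is expected to be small. On that basis compound 4 is estimated at 2500 nM, with a range from 900 nM to 7000 nM.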

Compound 4, concentration for total growth inhibition: 2060 nM
Beside the measured number, compound 4's estimate is 1.2-fold (0.08 log units) above it, and the stated range covers the measured number.
By their numbers in this assay, from the lowest: compounds 4, 3 and 2 (each within the scatter of the next); then compound 1.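

This is the first change shown at the oxygen on the aromatic ring, and in this assay it gives a 1.2-fold lower number from compound 3 to compound 4 (0.09 log units; within the scatter), so the numbers for the two compounds cannot be told apart. Methoxy can therefore give way to hydroxy in this pair, with a methyl leaving and a hydrogen taking its place on that oxygen, without a difference beyond the usual scatter of the assay. This result speaks only to the oxygen and its methyl, whereas the earlier steps concerned the chloro on an aromatic carbon and the group on the carbonyl carbon, and no accompanying measurement explains the result.

The compounds shown leave open how an amino group or a longer chain such as ethoxy would read at this place on the ring. They also leave open whether methoxy and hydroxy would read alike with the groups on the carbonyl carbon found in compound 1 and compound 2, as this change is shown only with the group in compound 3.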